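Ethoxycarbonyl to methoxycarbonyl in compound 3

The compounds below may be only part of what the source reports. "The series", "measured", "known", "first", "only" and "open" are said of these compounds alone.

In a functional assay on HL-60 cells (Homo sapiens) for cytotoxicity, read by MTT assay, with a stated time of 72 h (a higher number here means a weaker inhibitor, a lower number a stronger inhibitor), compound 1 `CCOC(=O)c1sc2ccccc2c1Nc1cc(OC)c(OC)c(OC)c1` gives 5490 nM and compound 3 `CCOC(=O)c1sc2cccc(C)c2c1Nc1cc(OC)c(OC)c(OC)c1` gives 7390 nM. These two values lie within the scatter of each other, while compound 2 `COC(=O)c1sc2nc(C)ccc2c1Nc1cc(OC)c(OC)c(OC)c1`, at 0.4 nM, lies far below both. Compound 3 therefore stands at the weak end of this small set, level with compound 1.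

The next compound, compound 4 `COC(=O)c1sc2cccc(C)c2c1Nc1cc(OC)c(OC)c(OC)c1`, is made by one change: hydrogen in place of methyl on a saturated chain carbon bound to an oxygen next to a carbonyl group, that is, ethoxycarbonyl to methoxycarbonyl. Going by the values given here, no measured step isolates this change. The only one available, a 1.3-fold higher number from compound 1 to compound 3 (0.13 log units; within the scatter), concerns methyl in place of hydrogen on an aromatic carbon, a different place. Compound 2 also carries methoxycarbonyl, but its core differs as well, so its 0.4 nM cannot be credited to that group alone. Only a modest move toward a lower number is therefore expected, namely a 2.5-fold lower number from compound 3 to compound 4 (0.39 log units; beyond the scatter). Compound 4 is estimated at 3000 nM, with an expected range from 200 nM to 12000 nM.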

Compound 4, half-maximal inhibitory concentration: 3390 nM
Compound 4: the middle estimate sits 1.1-fold (0.05 log units) below what was measured; measured number inside the range.
By their numbers in this assay, from the lowest: compound 2; then compounds 4, 1 and 3 (each within the scatter of the next, the first and the last beyond it).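

In this assay, the ester group now has a step of its own: ethoxycarbonyl to methoxycarbonyl gives a 2.2-fold lower number from compound 3 to compound 4 (0.34 log units; beyond the scatter). Going by these compounds alone, this is the first step between compounds differing in one place that lies beyond the scatter, so this position responds to a change, whereas the only earlier such step, on an aromatic carbon, did not. The step is modest, however, and it has been read on the core of compound 3 alone. Nothing available explains why removing this methyl shifts the number.

The compounds shown leave open whether the same change would move the number by a similar amount on the core of compound 1 or of compound 2. They also leave open how a carboxylic acid, an amide or a longer chain such as propoxycarbonyl would read at this place.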